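Quinazoline thioacetamide series: aryl swap at the anilino nitrogen

A few compounds are considered here, and "the series" means these few. Any claim that something is new, unique, unknown or untested is made for them only; others in the source may bear on it.

Measured so far:
compound 1, `O=C(CSc1nc(Nc2ccccc2)c2ccccc2n1)Nc1ccc(Cl)cc1Cl`: 19400 nM
compound 2, `C=CC(=O)Nc1cccc(NC(=O)CSc2nc(Nc3cccc(Br)c3)c3ccccc3n2)c1`: 19400 nM

In a functional assay on MDA-MB-231 cells (Homo sapiens) for inhibition, read by MTT assay, with a stated time of 72 h (on this read-out higher numbers stand for weaker inhibition and lower numbers for stronger inhibition), compound 1 gives 19400 nM. In this assay compound 2 gives 19400 nM, so the two measured compounds stand level at the digits recorded, within the scatter of each other; no order between them can be read from these numbers.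

Compound 3, `C=CC(=O)Nc1cccc(NC(=O)CSc2nc(Nc3ccc(Cl)c(Cl)c3)c3ccccc3n2)c1`, has not yet been measured in this assay. It differs from compound 2 in one place: 3,4-dichlorophenyl in place of 3-bromophenyl on a nitrogen on an aromatic ring. Both measured compounds, with different aryl groups on that nitrogen and on the amide, sit at the same value, which gives no reason to expect the change to compound 3 to move the read-out.

The step of a 1.0-fold lower number from compound 2 to compound 3 (0.01 log units; within the scatter) is expected to be no larger than the scatter. In this assay compound 3 is estimated at 19000 nM, with a range from 8000 nM to 45000 nM.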

Compound 3, half-maximal inhibitory concentration: 17700 nM
The estimate for compound 3 lay 1.1-fold (0.03 log units) above the measured number; low and high end bracket the measured number.
By their numbers in this assay, from the lowest: compounds 3, 1 and 2 (each within the scatter of the next).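

In this assay, 3,4-dichlorophenyl in place of 3-bromophenyl on a nitrogen on an aromatic ring gives a 1.1-fold lower number from compound 2 to compound 3 (0.04 log units; within the scatter). This is the only comparison shown that isolates this position: with the rest of compound 2 held fixed, exchanging one bromine for two chlorine atoms on the phenyl ring leaves the two compounds level. No measurement is available that bears on the reason for this result.

Among these compounds, the one-place comparison covers only two halogen-bearing phenyl groups, so it remains open whether a phenyl carrying an amine or a carboxylic acid on this nitrogen would stay level with them. Compound 1 differs from compound 2 in more than one place, which leaves the contribution of the aryl group on the amide unresolved.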